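A Carbamoyl Chain in Place of Propyl on the Aromatic Nitrogen

The source may hold more compounds than are shown below. What is called first, only, known or untested is meant among the compounds shown, and "the series" means these compounds.

Among the compounds with values here, compound 1 (`COc1ncc(-c2ccc3nc(NC(=O)NCCN4CCCC4)sc3c2)cc1NS(=O)(=O)c1ccc(F)cc1`) gives 310 nM in a functional assay on HCT-116 cells (Homo sapiens) for antiproliferative activity, read by MTT assay, with a stated time of 72 h (on this read-out higher numbers stand for weaker inhibition and lower numbers for stronger inhibition), and compound 2 (`COc1ncc(-c2ccc3nc(NC(=O)NCCN4CCCCC4)sc3c2)cc1NS(=O)(=O)c1ccc(F)cc1`) gives 610 nM; the step of a 2.0-fold higher number from compound 1 to compound 2 (0.29 log units; within the scatter) is the only measured step here. Compound 3 (`CCCNc1nc2ccc(-c3cnc(Cl)c(NS(=O)(=O)c4ccc(F)cc4)c3)cc2s1`) gives only a limit in this assay, > 20000 nM. That is the limit of > 20000 nM in this assay, at which 1 of the 3 values shown sits, so compound 3 stands at the weak end of the numbers shown. Compound 4 (`CCN(CC)CCNC(=O)Nc1nc2ccc(-c3cnc(Cl)c(NS(=O)(=O)c4ccc(F)cc4)c3)cc2s1`) differs from compound 3 in one place: (2-(diethylamino)ethyl)carbamoyl in place of propyl on a nitrogen on an aromatic ring. Within the data shown here, no measured step covers this change; compounds 1 and 2 merely show that carbamoyl-bearing analogues with basic side chains reach measurable numbers. Compound 4 is therefore expected to move well away from the limit, with an estimated step of an at least 13-fold lower number from compound 3 to compound 4 (1.12 log units; beyond the scatter). Compound 4 is estimated at 1500 nM, within 300 nM to 8000 nM.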

Compound 4, half-maximal inhibitory concentration: 920 nM
For compound 4 the middle estimate is 1.6-fold (0.21 log units) above the measured one, within the range that was stated.
By their numbers in this assay, from the lowest: compounds 1, 2 and 4 (each within the scatter of the next, the first and the last beyond it). At a limit, above all of these: compound 3.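

In this assay, within the data shown here, (2-(diethylamino)ethyl)carbamoyl in place of propyl on a nitrogen on an aromatic ring gives an at least 21-fold lower number from compound 3 to compound 4 (1.33 log units; beyond the scatter), the first measured step at this position and one that leaves the limit behind. The value of compound 3 is a limit of the assay and not a number: the limit of > 20000 nM in this assay, at which 1 of the 4 values shown sits.

The step therefore has a floor but no exact size. The compounds shown leave open whether the carbamoyl alone carries this step, as an unsubstituted carbamoyl or an acetyl on that nitrogen would show. Also open, on these data alone, is how a longer chain, or a carboxylic acid in place of the diethylamino group, would read.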